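The source may hold more compounds than are shown below. What is called first, only, known or untested is meant among the compounds shown, and "the series" means these compounds.

Compound 1 `C=CCc1cc(C(C)=O)c(O)cc1OCCCCCCC`: 8%
Compound 2 `C=CCc1cc(C(C)=O)c(O)cc1OCCCCCC(=O)OC`: 65%

In an assay on isolated protein for binding affinity to leukotriene B4 receptor 1 (Homo sapiens), tested at 1 uM (a higher number here means more inhibition at the concentration tested (going by the name of the read-out), a lower number less inhibition), compound 2 stands highest of the two numbers, above compound 1 by the large step of a number 57 percentage points higher from compound 1 to compound 2 (beyond the scatter). Compound 3 `C=CCc1cc(C(C)=O)c(O)cc1OCCCCCC(=O)NO` differs from compound 2 by hydroxyamino in place of methoxy on a carbonyl carbon. Within the data shown here, no measured step covers an exchange at this carbonyl carbon; the one step known touches the same chain end and shows that what sits there matters much. The direction for compound 3 is therefore open, and only a step within the scatter, a number 3 percentage points lower from compound 2 to compound 3 (within the scatter), is expected. Compound 3 is estimated at 62%, between 35% and 85%.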

Compound 3, a percentage reported as inhibition, at one concentration (the size of the read-out at that concentration, not a potency): 28%
Estimate against measurement, compound 3: 34 percentage points above; measured number below the stated range.
By their numbers in this assay, from the lowest: compound 1; then compound 3; then compound 2.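

In this assay the carbonyl carbon proves sensitive to what it carries: hydroxyamino in place of methoxy gives a number 37 percentage points lower from compound 2 to compound 3 (beyond the scatter), so a carbonyl at the chain end does not by itself hold the level of compound 2. The hydroxycarbamoyl end still keeps part of the gain over the ethyl end, with a number 20 percentage points higher from compound 1 to compound 3 (beyond the scatter). No measurement at hand accounts for this difference. As far as these compounds go, whether a carboxylic acid or a primary amide on this carbonyl carbon would stand nearer compound 2 or compound 3 remains open, and so does the effect of a longer chain.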